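Swapping one halogen on an aryl ring: chloro to fluoro

The source may hold more compounds than are shown below. What is called first, only, known or untested is meant among the compounds shown, and "the series" means these compounds.

Compound 1 `COc1ccc(/C=N/NC(=O)Nc2ccc(Oc3ccnc4cc(OCCCN5CCC(C)CC5)c(OC)cc34)c(F)c2)cc1` — 430 nM
Compound 2 `COc1cc2c(Oc3ccc(NC(=O)N/N=C/c4ccc(Cl)cc4Cl)cc3F)ccnc2cc1OCCCN1CCC(C)CC1` — "not determined" (no result reported)

The three compounds share one large core and differ only in the small aryl group hanging off the hydrazone end. In a functional assay on A549 cells (Homo sapiens) for cytotoxicity, read by MTT assay, with a stated time of 72 h (a higher number here means a weaker inhibitor, a lower number a stronger inhibitor), compound 1 gives 430 nM. Compound 2 carries a 2,4-dichlorophenyl group in the same place, but for compound 2 the entry in this assay reads "not determined" (no result reported), so nothing can be said about where it stands relative to compound 1.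

Compound 3 `COc1cc2c(Oc3ccc(NC(=O)N/N=C/c4ccc(F)cc4Cl)cc3F)ccnc2cc1OCCCN1CCC(C)CC1` is the next analogue. The change from compound 2 to compound 3 is fluoro in place of chloro on an aromatic carbon. Within the data shown here, no measured pair shows what this kind of swap does here, so no step size can be quoted from the data. Given how close the three structures are, the expectation is that compound 3 lands near the value of compound 1 rather than far from it, with a shift, if any, that stays within the usual scatter. Compound 3 is therefore estimated at 500 nM in this assay, within a range of 150 nM to 2000 nM.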

Compound 3, half-maximal inhibitory concentration: 190 nM
The estimate for compound 3 lay 2.6-fold (0.42 log units) above the measured number; the range from low to high includes it.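

In this assay, putting 2-chloro-4-fluorophenyl in place of 4-methoxyphenyl on the carbon with a double bond to nitrogen gives a 2.3-fold lower number from compound 1 to compound 3 (0.35 log units; beyond the scatter), a modest step but one beyond the scatter. Among these compounds, this is the first sign that the small aryl group at the hydrazone end can change the read-out while the shared core stays the same, and that a ring carrying two halogens still gives a sub-micromolar-range number here, with compound 3 at 190 nM. The chloro to fluoro swap itself cannot be read, since compound 2 has no number to compare with, and nothing measured explains the step seen between the other two compounds.

The step from compound 1 to compound 3 replaces a whole substituted ring, so the compounds shown leave open how much of it belongs to the chloro group and how much to the fluoro group, which a plain 4-fluorophenyl or 2-chlorophenyl group would help to separate. Also open, as far as these compounds go, is how a different kind of group on this ring, such as a dimethylamino group or a carboxylic acid, would behave in this assay.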